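This account rests on a few compounds, and the source may have more. Where it says the series, first, only, none or still open, it means among the compounds named here.

Compound 3 `Cc1cccc(C#Cc2ccc3c(n2)CCN(C(C)C)C3=O)c1` gives, in a functional assay on HEK293 cells for negative allosteric modulation of metabotropic glutamate receptor 5 (Homo sapiens), read by FLIPR and calcium flux (on this read-out higher numbers stand for weaker inhibition and lower numbers for stronger inhibition), a value of 4.8 nM. Among the three measured compounds it has the second highest number. Its nearest neighbour is compound 1 `Cc1cccc(C#Cc2ccc3c(n2)CCN(C)C3=O)c1`, which in this assay gives 2.9 nM; the step of a 1.7-fold higher number from compound 1 to compound 3 (0.22 log units; within the scatter) lies within the scatter. Furthest from it is compound 2 `CN1CCc2nc(C#Cc3ccccn3)ccc2C1=O`, which in this assay gives 184 nM; no step between compound 3 and compound 2 has been worked out, but the two values lie far apart. Compound 4 `CC(C)N1CCc2nc(C#Cc3ccccn3)ccc2C1=O` has not yet been measured. It differs from compound 3 in one place: pyridin-2-yl in place of 3-methylphenyl on a triple-bonded carbon. For the measured compounds named here, one measured step bears directly on this change, namely a 63-fold higher number from compound 1 to compound 2 (1.80 log units; beyond the scatter), where the same exchange on a triple-bonded carbon was made. The other difference between the pairs, isopropyl in place of methyl on the amide-type nitrogen in the ring, gave only a 1.7-fold higher number from compound 1 to compound 3 (0.22 log units; within the scatter). A comparable step is expected here. Compound 4 is therefore estimated at 300 nM, within 100 nM to 900 nM, an expected step of a 63-fold higher number from compound 3 to compound 4 (1.80 log units; beyond the scatter).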

Compound 4, half-maximal inhibitory concentration: 27 nM
Compound 4: middle estimate off by 11-fold (1.05 log units), on the high side; the whole stated range lies above it.
By their numbers in this assay, from the lowest: compounds 1 and 3 (each within the scatter of the next); then compound 4; then compound 2.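

In this assay, pyridin-2-yl in place of 3-methylphenyl on a triple-bonded carbon still raises the number when the amide-type nitrogen carries isopropyl, but the step is much smaller on this core: (the same change on two cores in this assay, a 63-fold higher number (1.80 log units; beyond the scatter) from compound 1 to compound 2 and a 5.6-fold higher number (0.75 log units; beyond the scatter) from compound 3 to compound 4, 11-fold (1.05 log units) apart, beyond the scatter of two such steps). Isopropyl in place of methyl on that nitrogen, which made no difference beyond the scatter with 3-methylphenyl, lowers the number with pyridin-2-yl (a 6.8-fold lower number from compound 2 to compound 4 (0.83 log units; beyond the scatter)): (the same change on two cores in this assay, a 1.7-fold higher number (0.22 log units; within the scatter) from compound 1 to compound 3 and a 6.8-fold lower number (0.83 log units; beyond the scatter) from compound 2 to compound 4, 11-fold (1.05 log units) apart, beyond the scatter of two such steps). Across these four compounds the two changes therefore do not act independently, and the size of each step depends on the group at the other place, as the step (a 5.6-fold higher number from compound 3 to compound 4 (0.75 log units; beyond the scatter)) also shows.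

The compounds shown do not tell why the two places are coupled. From the compounds shown here alone, it remains open whether the coupling extends to a cyclopropyl or 2-hydroxyethyl group on the nitrogen, or to pyrimidin-2-yl or 3-fluorophenyl on the triple-bonded carbon.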